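The compounds below may be only part of what the source reports. "The series", "measured", "known", "first", "only" and "open" are said of these compounds alone.

Values so far in a functional assay on QG-56 cells (Homo sapiens) for cytotoxicity, read by MTT assay, with a stated time of 48 h (a lower number here means a stronger inhibitor, a higher number a weaker inhibitor), for the series:
- compound 1 `COc1cc(/C=C/C(=O)C2=C(/C=C/c3ccc(O)c(OC)c3)NC(=O)NC2c2ccc(C)cc2)ccc1O` gives 100000 nM
- compound 2 `COc1cc(/C=C/C(=O)C2=C(/C=C/c3ccc(O)c(OC)c3)NC(=O)NC2c2ccccc2Cl)ccc1O` gives 100000 nM
- compound 3 `COc1cc(/C=C/C(=O)C2=C(/C=C/c3ccc(O)c(OC)c3)NC(=S)NC2c2ccc(C)cc2)ccc1O` gives 12500 nM

Compound 3 has the lowest number of the three, and both other values lie beyond the scatter above it. Next is compound 4 `COc1cc(/C=C/C(=O)C2=C(/C=C/c3ccc(O)c(OC)c3)NC(=S)NC2c2c(Cl)cccc2Cl)ccc1O`, with this change from compound 3: 2,6-dichlorophenyl in place of 4-methylphenyl on a saturated ring carbon. Among the compounds with values here, the only measured step at this place is no change at the digits printed from compound 1 to compound 2 (within the scatter) and it is a thin guide, taken at much higher numbers with a different entering group. No step beyond the scatter is therefore expected in this assay and the expected outcome is no change at the digits printed from compound 3 to compound 4 (within the scatter) as estimated here. Compound 4 is estimated at 12500 nM (range 4000 nM to 40000 nM) in this read-out.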

Compound 4, half-maximal inhibitory concentration: 100000 nM
Compound 4: the middle estimate sits 8.0-fold (0.90 log units) below what was measured; the whole stated range lies below it.
By their numbers in this assay, from the lowest: compound 3; then compounds 1, 2 and 4 (each within the scatter of the next).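

In this assay the change to 2,6-dichlorophenyl gives an 8.0-fold higher number from compound 3 to compound 4 (0.90 log units; beyond the scatter), so this saturated ring carbon does respond to its aryl group, which no change at the digits printed from compound 1 to compound 2 (within the scatter) did not show. Compound 4 at 100000 nM prints the same value as compounds 1 and 2, leaving compound 3 alone apart from the rest. No supporting data bear on this step.

Open, on these data alone, is what a 4-aminophenyl or 4-carboxyphenyl group would give here with the compound 3 core, and whether 2-chlorophenyl alone would match 2,6-dichlorophenyl on that core.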